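This account rests on a few compounds, and the source may have more. Where it says the series, first, only, none or still open, it means among the compounds named here.

Of the compounds shown here, two carry numbers so far. In a functional assay on BJAB cells (Homo sapiens) for antiproliferative activity, with a stated time of 4 days (on this read-out lower numbers stand for an effect already at smaller amounts and higher numbers for an effect only at larger amounts of compound), compound 1 `Cc1nn(-c2nc(-c3ccc(Cl)c(Cl)c3)c(SC(C)C)s2)c(C(=O)O)c1Cc1ccccc1[N+](=O)[O-]` gives 20000 nM. Compound 2 `Cc1nn(-c2nc(-c3ccc(Cl)c(Cl)c3)c(SC(C)C)s2)c(C(=O)O)c1-c1cc(C#N)cc(C(F)(F)F)c1` gives 3600 nM in the same assay, the lower of the two numbers. Among the compounds with values here, the only step between measured compounds is a 5.6-fold lower number from compound 1 to compound 2 (0.74 log units; beyond the scatter).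

Compound 3 `COc1cc(C#N)cc(-c2c(C)nn(-c3nc(-c4ccc(Cl)c(Cl)c4)c(SC(C)C)s3)c2C(=O)O)c1` has not been measured. It differs from compound 2 by methoxy in place of trifluoromethyl on an aromatic carbon, the exchange sitting on an aromatic carbon of a six-membered aromatic ring of carbon only, meta to a cyano group. That single measured step concerns a different group at a different place and offers no guide for putting methoxy where trifluoromethyl was. Within the data shown here, with no precedent, the expectation for this assay is a step that stays within the scatter, in either direction, a 1.1-fold higher number from compound 2 to compound 3 (0.05 log units; within the scatter). Compound 3 is therefore expected near 4000 nM, with a range of 1500 nM to 12000 nM.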

Compound 3, half-maximal effective concentration: 5200 nM
Beside the measured number, compound 3's estimate is 1.3-fold (0.11 log units) below it; low and high end bracket the measured number.
By their numbers in this assay, from the lowest: compounds 2 and 3 (each within the scatter of the next); then compound 1.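

At this place, meta to a cyano group, methoxy in place of trifluoromethyl gives a 1.4-fold higher number from compound 2 to compound 3 (0.16 log units; within the scatter) in this assay and so does not separate the two compounds, although the entering group has fewer heavy atoms and brings a hydrogen-bond acceptor. The exchange of 2-nitrobenzyl for 3-cyano-5-methoxyphenyl gives a 3.8-fold lower number from compound 1 to compound 3 (0.59 log units; beyond the scatter) as its step, so the difference from compound 1 seen with 3-cyano-5-(trifluoromethyl)phenyl also holds with methoxy at this place. Nothing available speaks to the reason for these numbers.

Open, from the compounds shown here alone, is whether an amine, a hydroxyl or a longer ether chain such as ethoxy at this place would give a step beyond the scatter. Also open, going by these compounds, is whether an amide in place of the carboxylic acid would change the numbers of this pair.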